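A few compounds are considered here, and "the series" means these few. Any claim that something is new, unique, unknown or untested is made for them only; others in the source may bear on it.

Working notes on the butenolide series, measured in a functional assay on SW-620 cells (Homo sapiens) for inhibition, read by MTT assay, with a stated time of 72 h; on this read-out lower numbers stand for stronger inhibition and higher numbers for weaker inhibition.

Of the compounds shown here, three have values so far. Compound 1 `O=C1O/C(=C\Cn2c(=O)[nH]c(=O)[nH]c2=O)C(OCc2ccccc2)=C1OCc1ccccc1` sits at the assay limit, giving > 100000 nM, which is a limit and not a number. Compound 2 `Nc1ncn(CCC2(N)OC(=O)C(OCc3ccccc3)=C2OCc2ccccc2)c(=O)n1` likewise reaches only the limit, with > 100000 nM in this assay. Compound 3 `Nc1ncn(C[C@H](O)[C@H]2OC(=O)C(OCc3ccccc3)=C2OCc2ccccc2)c(=O)n1` also gives a limit, > 100000 nM, in this assay. Going by the values given here, no step between measured compounds that differ in one place can be drawn, so where compound 2 stands is known only as far as the limit of > 100000 nM in this assay, at which 3 of the 3 values shown sit, and its value cannot be placed above or below those of compound 1 or compound 3.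

The next compound is compound 4 `Nc1ccn(CCC2(N)OC(=O)C(OCc3ccccc3)=C2OCc2ccccc2)c(=O)n1`. It differs from compound 2 by a group of 8 heavy atoms (4 carbon, 3 nitrogen, 1 oxygen; one six-membered aromatic ring with 2 hetero atoms) in place of a group of 8 heavy atoms (3 carbon, 4 nitrogen, 1 oxygen; one six-membered aromatic ring with 3 hetero atoms), on a saturated chain carbon, two bonds along the chain from a saturated ring carbon. Whether this change moves the read-out at all is not told by anything measured here; with every value at the limit, the expected step is none beyond the scatter, and the most likely outcome is that compound 4 also returns a limit. For compound 4 the expected step of a number no higher from compound 2 to compound 4 (the limit leaves the size open) is therefore essentially flat. Compound 4 is estimated at 100000 nM in this assay, within a range from 30000 nM to 300000 nM.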

Compound 4, half-maximal inhibitory concentration: > 100000 nM
Compound 4 gave a limit, no number; the forecaster's own chance of this, stated with the estimate: 80%; the middle value lies on the limit itself.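

In this assay compound 4 gives > 100000 nM, which is a limit and not a number. Compound 2 also stands at a limit, so no step can be read between compound 2 and compound 4. The compounds shown leave open whether any structural change here moves the read-out, as every result so far sits at one value: the limit of > 100000 nM in this assay, at which 4 of the 4 values shown sit.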